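Hydroxy for methoxy in one cytotoxicity assay

A few compounds are considered here, and "the series" means these few. Any claim that something is new, unique, unknown or untested is made for them only; others in the source may bear on it.

Readings in an ADME assay on NIH3T3 cells (Mus musculus) for cytotoxicity, read by MTT assay, with a stated time of 72 h; a lower number here means a stronger inhibitor, a higher number a weaker inhibitor:

compound 1 `COc1ccc(/C=C/C(=O)CC(C)=O)cc1` — 48200 nM
compound 3 `Cc1cc(/C=C/c2ccc(O)cc2)on1` — 88500 nM
compound 2 `COc1ccc(/C=C/c2cc(C)no2)cc1` — a limit, given below

Compound 2 sits at the limit of > 100000 nM in this assay, at which 1 of the 3 values shown sits; its reading > 100000 nM is a limit and not a number. Compound 3 carries hydrogen in place of methyl on an oxygen on an aromatic ring relative to compound 2, and the step is an at least 1.1-fold lower number from compound 2 to compound 3 (0.05 log units; that floor lies within the scatter). Compounds 1 and 3 are within the scatter of each other. How the core of compound 1 differs from that of compound 2 is not broken down here.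

Compound 4 `CC(=O)CC(=O)/C=C/c1ccc(O)cc1` is not yet measured. Against compound 1 it carries hydrogen in place of methyl on an oxygen on an aromatic ring, the same change as from compound 2 to compound 3. Since that step was an at least 1.1-fold lower number from compound 2 to compound 3 (0.05 log units; that floor lies within the scatter), the step from compound 1 to compound 4 is expected to be a 1.1-fold lower number from compound 1 to compound 4 (0.06 log units; within the scatter). Compound 4 is therefore estimated at 42000 nM, between 16000 nM and 100000 nM.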

Compound 4, half-maximal inhibitory concentration: 18900 nM
The estimate for compound 4 lay 2.2-fold (0.35 log units) above the measured number; the range from low to high includes it.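

In this assay, replacing methoxy with hydroxy on the core of compound 1 gives a 2.6-fold lower number from compound 1 to compound 4 (0.41 log units; beyond the scatter). A step beyond the scatter is therefore shown on this core only, and whether the change carries to the other core at the same size stays unsettled: the same change on two cores in this assay, an at least 1.1-fold lower number (0.05 log units; that floor lies within the scatter) from compound 2 to compound 3 and a 2.6-fold lower number (0.41 log units; beyond the scatter) from compound 1 to compound 4; the limit leaves it open whether they differ The reading of compound 2 is a limit and not a number, so the step on its core has only a floor: the limit of > 100000 nM in this assay, at which 1 of the 4 values shown sits.

The compounds shown leave open whether a longer chain on that oxygen, such as ethyl, or an amine in place of the hydroxy would shift the number in this assay. They also leave open how the change behaves on a third core.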